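The source may report more compounds than this note shows. Statements on the series, on what has been measured and on what is new or still open speak of the compounds shown alone.

Two compounds of the series have so far been run in a physicochemical assay for lipophilicity, using the shake flask method, at pH 7.4; on this read-out higher numbers stand for higher lipophilicity and lower numbers for lower lipophilicity. Compound 1 `CCCC(Oc1ccc(-n2cc(C#N)cn2)cc1)c1ccc(C(=O)NCCC(=O)O)cc1` gives 1.2 in this assay, the lowest of the two numbers available. Compound 2 `CCCC(Nc1cc(C)c(-n2cc(C(F)(F)F)cn2)c(C)c1)c1ccc(C(=O)NCCC(=O)O)cc1` gives 2.2 in this assay, a number that sits above compound 1 by more than the usual scatter; the two structures differ in several places at once, so nothing more is read into that gap than what the two values show. Compound 3 `CCCC(Oc1ccc(-n2cc(C(F)(F)F)cn2)cc1)c1ccc(C(=O)NCCC(=O)O)cc1` remains to be measured in this assay. Relative to compound 1 it carries a single change: trifluoromethyl in place of cyano on an aromatic carbon. Going by the values given here, no step between measured compounds covers this exchange on the shared core, so the expectation rests on the change itself rather than on a measured pair. Across this change the step is expected to be a number 1.10 log units higher from compound 1 to compound 3 (beyond the scatter), a rise beyond the scatter rather than a flat result. Compound 3 is therefore expected to read about 2.3 in this assay, with a plausible range from 1.8 to 2.8.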

Compound 3, distribution coefficient: 2.4
For compound 3 the middle estimate is 0.10 log units below the measured one, and the stated range covers the measured number.
By their numbers in this assay, from the lowest: compound 1; then compounds 2 and 3 (each within the scatter of the next).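

In this assay, going by these compounds alone, the exchange of cyano for trifluoromethyl on the aromatic carbon of the five-membered aromatic ring gives a number 1.20 log units higher from compound 1 to compound 3 (beyond the scatter) on the shared core, the first large step that can be read at a single place. This position is therefore not silent on this read-out: with the rest of the structure held constant, replacing a group of 2 heavy atoms and 1 hydrogen-bond acceptor with one of 4 heavy atoms and 0 hydrogen-bond acceptors is enough to move the number beyond the scatter. Nothing at hand accounts for the size of this step, and with one exchange at this place it remains a single observation rather than a trend.

From the compounds shown here alone, it remains open how an amine, a carboxylic acid or a simple methyl group would read on the same carbon, so the two groups compared here do not yet define a range for this position. Whether the exchange gives a step of similar size on the core of compound 2 could be read only with a cyano counterpart of compound 2.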